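Piperazine aryl swap at the weak end of the series

This account rests on a few compounds, and the source may have more. Where it says the series, first, only, none or still open, it means among the compounds named here.

Measured so far in an assay on membranes from liver for displacement of a labelled ligand from Sigma intracellular receptor 2 (Rattus norvegicus), read by scintillation counting, with a stated time of 120 min; on this read-out lower numbers stand for stronger inhibition and higher numbers for weaker inhibition:
compound 1 `Cc1cccc2sc(NC(=O)CCN3CCN(CC4CCCO4)CC3)nc12` — 5000 nM
compound 2 `Cc1ccccc1N1CCN(CCC(=O)Nc2nc3c(C)cccc3s2)CC1` — > 1000 nM (a limit, not a number)

Compound 1 sits at a weak value in this assay. For compound 2 this assay reports only a limit, > 1000 nM. Compound 2 therefore stands at the limit of > 1000 nM in this assay, at which 1 of the 2 values shown sits, and the step that the limit leaves unreadable from compound 1 to compound 2 cannot be sized. Compound 3 `Cc1cccc2sc(NC(=O)CCN3CCN(c4ccccn4)CC3)nc12` differs from compound 2 in one place: pyridin-2-yl in place of 2-methylphenyl on an amine nitrogen in a ring. Among the measured compounds shown here, no measured step covers a swap of one aryl group for another on the ring nitrogen; the single step recorded is itself unreadable. The expectation therefore rests on the weak range of the two measured values, with no direction assigned beyond the scatter, and a step that the limit leaves unreadable from compound 2 to compound 3 is the expected step. Compound 3 is estimated at 3000 nM, range 500 nM to 20000 nM, with a real chance that this assay again returns only a limit.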

Compound 3, inhibition constant: > 1000 nM
Compound 3 gave a limit, no number; the forecaster's own chance of this, stated with the estimate: 50%; the middle value is on the limit's open side.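

Compound 3 also gives only a limit, so the steps from compound 1 and from compound 2 to compound 3 cannot be read: the limit of > 1000 nM in this assay, at which 2 of the 3 values shown sit. The compounds shown leave open how pyridin-2-yl, 2-methylphenyl and (oxolan-2-yl)methyl on an amine nitrogen in a ring rank in this assay.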